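Longer chain to the same end group: outlook for compound 4

The compounds below may be only part of what the source reports. "The series", "measured", "known", "first", "only" and "open" are said of these compounds alone.

Measured so far:
Compound 1 `N#CNC(=N)NCCCn1nc(-c2ccccc2)ccc1=O`. In a functional assay on the whole organism (stomach) with Rattus norvegicus as the target (a higher number here means that more compound is needed for the effect, a lower number that less compound is needed), compound 1 gives > 100 mg/kg, which is a limit of the assay and not a number.
Compound 2 `CC/N=C(/NC#N)NCCCn1nc(C)ccc1=O`. In this assay compound 2 gives > 100 mg/kg, again only a limit.
Compound 3 `O=c1ccc(-c2ccccc2)nn1CCCCNC(=S)Nc1ccc(Cl)cc1`. In this assay compound 3 gives > 100 mg/kg, also a limit.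

Compound 1 therefore stands at the limit of > 100 mg/kg in this assay, at which 3 of the 3 values shown sit. No compound in the set has reached a numerical read-out, so no step between measured compounds can be stated and no size of change has been shown.

Compound 4 `N#CNC(=N)NCCCCCn1nc(-c2ccccc2)ccc1=O` is the next compound to be measured. Compared with compound 1 the change is a group of 8 heavy atoms (4 carbon, 4 nitrogen; no ring) in place of a group of 6 heavy atoms (2 carbon, 4 nitrogen; no ring), on a saturated chain carbon, three bonds along the chain from an aromatic nitrogen.

Because compound 1 sits at the limit of > 100 mg/kg in this assay, at which 3 of the 3 values shown sit, the measured data give no indication that a longer chain to the same end group would move the dose. In this assay the step is expected to be a step that the limit leaves unreadable from compound 1 to compound 4, that is, nothing beyond the scatter. Compound 4 is accordingly estimated at 150 mg/kg, within 60 mg/kg to 400 mg/kg, and most probably the assay will again report only a limit.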

Compound 4, dose for half-maximal effect: > 100 mg/kg
Compound 4 was reported as a limit (the forecaster's own chance of this, stated with the estimate: 75%); the middle value lies beyond the limit too.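

Compound 4 gives > 100 mg/kg in this assay, a limit of the assay and not a number, so no step can be read between compound 1 and compound 4: the limit of > 100 mg/kg in this assay, at which 4 of the 4 values shown sit.

The compounds shown leave open what dose any of them needs for the effect, and whether the group of 8 heavy atoms differs at all from the group of 6 heavy atoms.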